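Shortening the Ether Chain and Swapping Nitrile for Ester

The source may report more compounds than this note shows. Statements on the series, on what has been measured and on what is new or still open speak of the compounds shown alone.

Of the compounds shown here, two have been measured in an assay on isolated protein for inhibition of leukotriene B4 receptor 1 (Homo sapiens), tested at 10 uM; a higher number here means more inhibition at the concentration tested (going by the name of the read-out), a lower number less inhibition. Compound 1, `CC(=O)c1ccc(OCCCCC#N)cc1O`, carries a 5-cyanopentyl chain on the phenolic oxygen and gives 0% in this assay. Compound 2, `C=CCc1cc(C(C)=O)c(O)cc1OCCCCCCCCCCC#N`, adds an allyl group to the shared core and extends the chain to a 10-cyanodecyl; in this assay compound 2 gives 50%, the higher of the two numbers and beyond the scatter relative to compound 1. Compound 3, `C=CCc1cc(C(C)=O)c(O)cc1OCCCCCC(=O)OC`, keeps the allyl group of compound 2 but changes the chain: methoxycarbonyl in place of 5-cyanopentyl on a saturated chain carbon, five bonds along the chain from an oxygen on an aromatic ring. The chain thus becomes considerably shorter and ends in an ester rather than a nitrile. With compound 1 showing 0% on a short chain, a shorter chain is taken here as a likely loss, so the step of a number 25 percentage points lower from compound 2 to compound 3 (beyond the scatter) is expected to be a decrease, somewhat beyond the scatter. Compound 3 is therefore estimated to give 25% in this assay, within a range from 5% to 50%.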

Compound 3, a percentage reported as inhibition, at one concentration (the size of the read-out at that concentration, not a potency): 106%
Compound 3: middle estimate off by 81 percentage points, on the low side; measured number outside the range, above it.
By their numbers in this assay, from the lowest: compound 1; then compound 2; then compound 3.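

In this assay, putting methoxycarbonyl in place of 5-cyanopentyl on a saturated chain carbon, five bonds along the chain from an oxygen on an aromatic ring, gives a number 56 percentage points higher from compound 2 to compound 3 (beyond the scatter). The long chain ending in a nitrile is therefore not needed for inhibition at the concentration tested, at least with the allyl group in place, and this position can take a shorter chain ending in an ester with a clear gain. Nothing available here explains the rise.

The single change both shortens the chain and replaces the nitrile with an ester, so the compounds shown leave open which of the two carries the step; a chain the length of the one in compound 3 ending in a nitrile, or the long chain of compound 2 ending in methoxycarbonyl, would separate them. Also open, on these data alone, is how much the methoxycarbonyl end itself matters, which a carboxylic acid or an amide at the same place on the chain would begin to show.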